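The source may report more compounds than this note shows. Statements on the series, on what has been measured and on what is new or still open speak of the compounds shown alone.

In a functional assay on K562 cells (Homo sapiens) for cytotoxicity, read by trypan blue exclusion, with a stated time of 96 h (a lower number here means a stronger inhibitor, a higher number a weaker inhibitor), three compounds have been measured. Compound 1 `COc1ccc(CS(=O)(=O)/C=C/c2c(OC)cccc2OC)c([N+](=O)[O-])c1` gives 50000 nM, compound 2 `COc1ccc(CS(=O)(=O)/C=C/c2c(OC)cc(OC)cc2OC)c(N)c1` gives 25 nM, and compound 3 `COC(=O)CCNc1cc(CS(=O)(=O)/C=C/c2c(OC)cc(OC)cc2OC)ccc1OC` gives 1000 nM. Compound 3 therefore holds the second highest of the three numbers, and its gaps to both of the others lie beyond the scatter. No two of these compounds differ in one place only, so no measured step bears directly on what comes next.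

Compound 4 `COc1cc(OC)c(/C=C/S(=O)(=O)Cc2ccc(OC)c(NCCC(=O)O)c2)c(OC)c1` is derived from compound 3 by a single change, hydrogen in place of methyl on an oxygen next to a carbonyl group, which turns methoxycarbonyl into carboxy. The only pointer is compound 2, which at 25 nM shows that a much lower number is reachable among these compounds. In this assay, the expected 3.3-fold lower number from compound 3 to compound 4 (0.52 log units; beyond the scatter) is a moderate one towards a lower number, although a result within the scatter would not be surprising. Compound 4 is estimated at 300 nM, with an expected range from 40 nM to 2500 nM.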

Compound 4, half-maximal inhibitory concentration: 5000 nM
Beside the measured number, compound 4's estimate is 17-fold (1.22 log units) below it, outside the stated range (above it).
By their numbers in this assay, from the lowest: compound 2; then compound 3; then compound 4; then compound 1.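

In this assay, going by these compounds alone, replacing methoxycarbonyl with carboxy at the end of the side chain gives a 5.0-fold higher number from compound 3 to compound 4 (0.70 log units; beyond the scatter), the first step in this set that can be read at a single place. It shows that this end of the chain affects the number and that, for this pair, the change from methyl to hydrogen on the oxygen next to the carbonyl group moves it beyond the scatter towards a weaker inhibitor. Nothing given here explains why the number rises.

The compounds shown leave open whether a primary amide or an ethyl ester at this end of the chain would stay close to compound 3 or move towards compound 4. They also leave open whether a longer chain carrying the same carboxy group would change the number, and in which direction.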